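The compounds below may be only part of what the source reports. "The series", "measured", "known", "first", "only" and "open" are said of these compounds alone.

In an ADME assay on Vero cells (Chlorocebus sabaeus) for cytotoxicity (on this read-out lower numbers stand for higher toxicity in this test and higher numbers for lower toxicity in this test), compound 1 `C[C@]1(CO)O[C@@H](n2cc(I)c3c(N)ncnc32)[C@H](O)[C@@H]1O` gives 8080 nM. Compound 2 `C[C@]1(CO)O[C@@H](n2cc(-c3ccco3)c3c(N)ncnc32)[C@H](O)[C@@H]1O` gives > 50000 nM, which is a limit of the assay and not an exact number, so its true position on the scale is not known. Compound 3 `C[C@]1(CO)O[C@@H](n2cc(-c3ccsc3)c3c(N)ncnc32)[C@H](O)[C@@H]1O` is still unmeasured and carries thiophen-3-yl in place of furan-2-yl on an aromatic carbon. Among the measured compounds shown here, only one measured step bears on this change, an at least 6.1-fold higher number from compound 1 to compound 2 (0.79 log units; beyond the scatter), which lies beyond the scatter and puts furan-2-yl in place of iodo. That step shows what happens when iodo leaves, whereas here one five-membered aromatic ring with 1 hetero atom replaces another. No step beyond the scatter is therefore expected, with any shift more likely downward since compound 2 starts at the limit. The expected change is an at least 1.4-fold lower number from compound 2 to compound 3 (0.15 log units; that floor lies within the scatter). For compound 3 the estimated value is 35000 nM, with an expected range of 10000 nM to 50000 nM.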

Compound 3, half-maximal cytotoxic concentration: > 50000 nM
Compound 3: only a limit was reported (the forecaster's own chance of this, stated with the estimate: 55%); middle value at least 1.4-fold (0.15 log units) away from the limit.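

In this assay, thiophen-3-yl in place of iodo gives an at least 6.1-fold higher number from compound 1 to compound 3 (0.79 log units; beyond the scatter), so the earlier gain over iodo is not confined to furan-2-yl: a second five-membered aromatic ring with 1 hetero atom, here sulfur rather than oxygen, goes the same way on this aromatic carbon. Compound 3 is reported only as a limit. The step between furan-2-yl and thiophen-3-yl cannot be read, because both compounds sit at the same end of the scale: the limit of > 50000 nM in this assay, at which 2 of the 3 values shown sit.

On these data alone, whether these two rings differ at all in this test therefore stays open. As far as these compounds go, it is also open whether a group without an aromatic ring on this carbon, such as an aminomethyl group or a carboxylic acid, would give a number as high as the two rings do.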